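Replacing tert-butyl with phenyl in compound 1

The compounds below may be only part of what the source reports. "The series", "measured", "known", "first", "only" and "open" are said of these compounds alone.

Among the compounds with values here, only two compounds have numbers so far in a functional assay on the whole organism with Rattus norvegicus as the target; a lower number here means that less compound is needed, a higher number that more compound is needed for the effect. Compound 1 (`CC(C)(C)CCc1cc(C(F)(F)F)ccc1CNC(=O)Nc1cccc2[nH]ncc12`) gives 0.015 umol/kg, the lower of the two numbers, and compound 2 (`O=C(NCc1ccc(-c2ccccc2)nc1N1CCCCC1)Nc1cccc2[nH]ncc12`) gives 0.037 umol/kg, a gap that lies beyond the usual scatter.

Compound 3 (`O=C(NCc1ccc(C(F)(F)F)cc1CCc1ccccc1)Nc1cccc2[nH]ncc12`) has not yet been measured. It is compound 1 with a single change: phenyl in place of tert-butyl on a saturated chain carbon, two bonds along the chain from an aromatic carbon. Cut one bond further out, the same change reads 3,3-dimethylbutyl to phenethyl. Within the data shown here, no two measured compounds differ in one place only, so nothing measured so far shows directly how much such a swap matters in this assay.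

A modest rise seems more likely than a further fall, because compound 1 already sits at 0.015 umol/kg. The expected change is a 2.3-fold higher number from compound 1 to compound 3 (0.37 log units; beyond the scatter), a small step upward that may not clear the scatter. For compound 3 the estimated value is 0.035 umol/kg, with an expected range from 0.01 umol/kg to 0.12 umol/kg.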

Compound 3, dose for half-maximal effect: 0.03 umol/kg
Compound 3: middle estimate off by 1.2-fold (0.07 log units), on the high side, within the range that was stated.
By their numbers in this assay, from the lowest: compounds 1, 3 and 2 (each within the scatter of the next, the first and the last beyond it).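

In this assay, within the data shown here, the step of a 2.0-fold higher number from compound 1 to compound 3 (0.30 log units; within the scatter) gives the first direct reading of a single change, and it lies within the usual scatter, so compound 1 and compound 3 cannot be told apart here. At this place, on a saturated chain carbon, two bonds along the chain from an aromatic carbon, the open-chain tert-butyl and the six-membered aromatic phenyl ring therefore give numbers of the same standing, although phenyl brings more heavy atoms. No measurement shown here offers an explanation for this result.

This is one pair in one assay, so it cannot show whether the same place would also take a group with atoms other than carbon at the end of the chain, such as an amine or a carboxylic acid, or a longer chain carrying the phenyl ring. Compound 2 differs from compound 1 and compound 3 in more than one place, so it cannot settle these questions either.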